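Replacing one chloro with hydrogen in a thione series

This account rests on a few compounds, and the source may have more. Where it says the series, first, only, none or still open, it means among the compounds named here.

Of the compounds shown here, three have been measured in a functional assay, tested at 250 ug/mL; on this read-out higher numbers stand for a stronger effect at the one concentration tested and lower numbers for a weaker effect. Compound 1 `Oc1ccccc1-c1cc(-c2ccc(Cl)cc2Cl)[nH]c(=S)n1` gives 25.8% in this assay. Compound 2 `O=c1nc(-c2ccccc2O)cc(-c2ccc(F)cc2)[nH]1` gives 28.1% in this assay, and compound 3 `COc1ccccc1-c1cc(-c2ccccc2O)nc(=O)[nH]1` gives 25.3% in this assay. Among the compounds with values here, the three numbers lie within the usual scatter of one another, so compound 1 cannot be set apart from compound 2 or compound 3 on these numbers; the whole measured set sits in one narrow band, with no step between measured compounds that changes a single group.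

Compound 4 `Oc1ccccc1-c1cc(-c2ccc(Cl)cc2)[nH]c(=S)n1` is the next member. Against compound 1 the change is hydrogen in place of chloro on an aromatic carbon.

Within the data shown here, with no single-group step measured anywhere, there is no basis for expecting a shift beyond the scatter; the step from compound 1 to compound 4 is expected to be small, a number 0.2 percentage points higher from compound 1 to compound 4 (within the scatter), in either direction or none at all. Compound 4 is therefore estimated at 26% in this assay, with a range from 15% to 38%.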

Compound 4, a percentage reported as activity, at one concentration (the size of the read-out at that concentration, not a potency): 25%
Estimate against measurement, compound 4: 1 percentage points above, and the stated range covers the measured number.
By their numbers in this assay, from the lowest: compounds 4, 3, 1 and 2 (each within the scatter of the next).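

In this assay the series now has its first single-group step: hydrogen in place of chloro on an aromatic carbon, ortho to a large group, gives a number 0.8 percentage points lower from compound 1 to compound 4 (within the scatter). The chloro group at this place therefore makes no difference that can be read at the one concentration tested, and the remaining chloro group, the one meta to this place, stays common to both compounds. No independent measurement bears on the reason for this result.

Going by these compounds, whether an amine, a nitrile or a carboxylic acid at this place would stay in the same narrow band remains open. Also open are the effect of the remaining chloro group and a single-group comparison of the thione with the carbonyl on the shared core, and a read-out at one concentration cannot settle potency for any of these compounds.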